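Trimming the Benzyl Ring of a Sulfonamide Diamine

The source may report more compounds than this note shows. Statements on the series, on what has been measured and on what is new or still open speak of the compounds shown alone.

Of the compounds shown here, two built on a shared core have been measured in a functional assay on PANC-1 cells (Homo sapiens) for inhibition, read by MTT assay, with a stated time of 72 h; a lower number here means a stronger inhibitor of growth, a higher number a weaker inhibitor of growth. Compound 1 `O=S(=O)(NCCNCc1ccc(-c2ccccc2)cc1)c1cc(C(F)(F)F)cc(C(F)(F)F)c1` gives 4200 nM. Compound 2 `COc1ccc(CNCCCNS(=O)(=O)c2cc(C(F)(F)F)cc(C(F)(F)F)c2)cc1OC` gives 18000 nM, the higher of the two numbers and so the weaker inhibitor of growth, with a gap to compound 1 that lies beyond the usual scatter. The two compounds differ in more than one place. No single change is shown for that gap. Compound 3 `O=S(=O)(NCCCNCc1ccccc1)c1cc(C(F)(F)F)cc(C(F)(F)F)c1` has not yet been measured. It differs from compound 2 in one place: phenyl in place of 3,4-dimethoxyphenyl on a saturated chain carbon bound to an amine nitrogen. For the measured compounds named here, no measured pair shows this change on its own, so its effect is uncertain. The expected outcome is a modest move toward a lower number, a 1.8-fold lower number from compound 2 to compound 3 (0.26 log units; within the scatter), which may still sit within the ordinary scatter of repeat measurements. Compound 3 is estimated at 10000 nM, within a range from 3000 nM to 35000 nM.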

Compound 3, concentration for 50% growth inhibition: 16000 nM
Estimate against measurement, compound 3: 1.6-fold (0.20 log units) below; the measured number falls inside the stated range.
By their numbers in this assay, from the lowest: compound 1; then compounds 3 and 2 (each within the scatter of the next).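

In this assay, phenyl in place of 3,4-dimethoxyphenyl on a saturated chain carbon bound to an amine nitrogen gives a 1.1-fold lower number from compound 2 to compound 3 (0.05 log units; within the scatter). For the compounds shown here, this is the first single change that can be read on its own, and it shows that, for this pair, the methoxy groups of 3,4-dimethoxyphenyl make no difference that can be told from the scatter. No measurement is available that could explain this result.

From the compounds shown here alone, whether any other group at this place would shift the number remains open, for example a chlorine or a nitrile on the phenyl, or a carboxylic acid. No single change links compound 1 to the other two compounds, so what sets its number apart also remains unresolved.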